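A few compounds are considered here, and "the series" means these few. Any claim that something is new, unique, unknown or untested is made for them only; others in the source may bear on it.

In a functional assay on MCF7 cells (Breast, Homo sapiens) for inhibition (on this read-out higher numbers stand for weaker inhibition of growth and lower numbers for stronger inhibition of growth), compound 1 (`Nc1ccc(-c2nc3cc(F)ccc3s2)cc1`) gives < 10 nM, which is a limit of the assay and not a number. Compound 2 (`Nc1ccc(-c2nc3cc(F)ccc3s2)cc1I`) carries an iodo group on the same core. In this assay, compound 2 gives < 10 nM, which is also a limit. Compound 2 therefore has no exact position on the scale, and the only other result available is no more exact: the limit of < 10 nM in this assay, at which 2 of the 2 values shown sit.

Compound 3 (`Nc1ccc(-c2nc3cc(F)ccc3s2)cc1Br`) makes one change to compound 2, with bromo in place of iodo on an aromatic carbon, ortho to an amino group: bromo in place of iodo on an aromatic carbon. Among the measured compounds shown here, one measured step bears on this change, since it concerns the same aromatic carbon: a step that the two limits leave unreadable from compound 1 to compound 2. As far as these compounds go, both ends of that step are limits, so its size is unknown and it offers only weak guidance. On that basis, no step beyond the usual scatter is expected in this assay, and no direction can be favoured. The estimated step is a step that the limit leaves unreadable from compound 2 to compound 3. Compound 3 is expected to give about 5 nM, with an estimated range of 1 nM to 20 nM.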

Compound 3, concentration for 50% growth inhibition: < 10 nM
Compound 3: a limit, no number (the forecaster's own chance of this, stated with the estimate: 80%); the middle value lies beyond the limit too.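

No step can be read between compound 1, compound 2 and compound 3 in this assay, because all three results are limits and not numbers: the limit of < 10 nM in this assay, at which 3 of the 3 values shown sit.

The compounds shown leave open whether hydrogen, iodo and bromo on this aromatic carbon differ at all in their inhibition of growth, and if so, in which order and by how much.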